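The source may report more compounds than this note shows. Statements on the series, on what has been measured and on what is new or still open speak of the compounds shown alone.

Measured so far in a functional assay on the whole organism for inhibition, with Rattus norvegicus as the target; on this read-out higher numbers stand for an effect only at larger amounts of compound and lower numbers for an effect already at smaller amounts:

- Compound 1 `CC(C)c1ccc(OC(Cc2ccc(Cl)cc2)C(=O)O)cc1`: 10 mg/kg
- Compound 2 `O=C(O)C(Cc1ccc(Cl)cc1)Oc1ccccc1`: > 25 mg/kg
- Compound 3 `COc1ccc(OC(Cc2ccc(Cl)cc2)C(=O)O)cc1`: > 25 mg/kg

The entries for compound 2 and compound 3 are limits of the assay, not numbers. Compound 3 therefore stands at the limit of > 25 mg/kg in this assay, at which 2 of the 3 values shown sit. Only compound 1 has a true number in this set.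

Compound 4 `CC(C)(C)c1ccc(OC(Cc2ccc(Cl)cc2)C(=O)O)cc1` has not been measured yet. It carries tert-butyl in place of methoxy on an aromatic carbon, para to a large group: tert-butyl in place of methoxy on an aromatic carbon.

For the measured compounds named here, two measured steps bear on this change. Methoxy in place of isopropyl gave an at least 2.5-fold higher number from compound 1 to compound 3 (0.39 log units; beyond the scatter), and hydrogen in place of isopropyl gave an at least 2.5-fold higher number from compound 1 to compound 2 (0.39 log units; beyond the scatter). Both are at least modest and lie beyond the scatter. The remaining comparison, a step that the two limits leave unreadable from compound 2 to compound 3, offers no guide.

Tert-butyl is an all-carbon group, like the isopropyl of compound 1, so compound 4 is expected to fall near compound 1 rather than stay at the limit. That means a lower number than compound 3, and the change is expected to be an at least 2.5-fold lower number from compound 3 to compound 4 (0.39 log units; beyond the scatter). Compound 4 is estimated at 10 mg/kg, with an expected range from 4 mg/kg to 25 mg/kg.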

Compound 4, dose for half-maximal effect: 25 mg/kg
Beside the measured number, compound 4's estimate is 2.5-fold (0.40 log units) below it, and the stated range covers the measured number.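

In this assay, methyl in place of hydrogen on a saturated chain carbon bound to an aromatic carbon and two saturated chain carbons gave a 2.5-fold higher number from compound 1 to compound 4 (0.40 log units; beyond the scatter). A small addition of carbon here therefore changes the dose needed, and the larger all-carbon group needs more compound, so among these two groups bigger does not mean better. Still, compound 4 gives 25 mg/kg, a true number, so tert-butyl joins isopropyl as a group with a readable effect. Tert-butyl in place of methoxy gave a number no higher from compound 3 to compound 4 (the limit leaves the size open), and tert-butyl in place of hydrogen gave a number no higher from compound 2 to compound 4 (the limit leaves the size open). The size of these two steps cannot be read because each starts from a limit of the assay: the limit of > 25 mg/kg in this assay, at which 2 of the 4 values shown sit.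

Two all-carbon groups cannot show whether the best size lies below isopropyl, so an ethyl group at this place remains an open case, as does a larger one such as a cyclohexyl ring. Going by these compounds, it also stays open whether a carbon group is needed at all, or whether a chlorine atom or a dimethylamino group at the same place would give a readable effect too.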